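This account rests on a few compounds, and the source may have more. Where it says the series, first, only, none or still open, it means among the compounds named here.

Series notes, binding at the type 2 enzyme. Three compounds have been taken through an assay on HEK293 cells for binding affinity to 11-beta-hydroxysteroid dehydrogenase type 2 (Homo sapiens), read by scintillation proximity assay (a lower number here means a stronger inhibitor, a higher number a weaker inhibitor), so far. Compound 1 `CCCC1(C)SC(NCC2CCCCC2)=NC1=O` carries a cyclohexylmethyl group on the amine and is recorded as "not determined" (no result reported) in this assay. Compound 2 `CCCC1(C)SC(NC23CCC(CC2)C3)=NC1=O` carries a bicyclic amine on the same core and is likewise recorded as "not determined" (no result reported) in this assay. Compound 3 `CCC1SC(Nc2ccccc2C)=NC1=O`, with an ethyl group on the core and an aryl amine, reaches only a limit of this assay; compound 3 gives > 10000 nM, and that is a limit, not a number. Where compound 2 stands is therefore open: there is no number for it, and the only quantitative entry in the set is the limit given by the limit of > 10000 nM in this assay, at which 1 of the 3 values shown sits.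

The next compound, compound 4 `CCC1(C)SC(NC23CCC(CC2)C3)=NC1=O`, keeps the bicyclic amine of compound 2 and changes one substituent: hydrogen in place of methyl on a saturated chain carbon, two bonds along the chain from a saturated ring carbon. Among the compounds with values here, with no step yet measured between any two compounds of this set, the size of this change in this assay cannot be read from the data; the working expectation is no step beyond the scatter, with the read-out most likely again at the limit. Compound 4 is estimated at 15000 nM, with a range from 3000 nM to 60000 nM.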

Compound 4, half-maximal inhibitory concentration: > 10000 nM
Compound 4 ended at the assay's limit; the forecaster's own chance of this, stated with the estimate: 80%; the middle value does not contradict the limit.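

Compound 4 gives > 10000 nM in this assay, and that is a limit, not a number. Compound 2 has no single number, so no step can be read between compound 2 and compound 4. The compounds shown leave open how large a step the change from methyl to hydrogen makes: the limit of > 10000 nM in this assay, at which 2 of the 4 values shown sit.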